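Furan versus butenolide side chain on two cores

The compounds below may be only part of what the source reports. "The series", "measured", "known", "first", "only" and "open" are said of these compounds alone.

Compound 1 `CC(=O)O[C@@H]1CC[C@]2(C)C(CCc3ccoc3)=C(C)C(=O)[C@@H](O)[C@H]2C1(C)C` and compound 2 `CC(=O)O[C@@H]1CC[C@]2(C)C(CCC3=CCOC3=O)=C(C)C(=O)[C@@H](O)[C@H]2C1(C)C` share one core; compound 3 `CCC(=O)[C@H]1O[C@@](CCC2=CCOC2=O)(OC)[C@@]2(C)CCCC(C)(C)[C@H]12` and compound 4 `CCC(=O)[C@H]1O[C@@](CCc2ccoc2)(OC)[C@@]2(C)CCCC(C)(C)[C@H]12` share another. In a functional assay on RAW264.7 cells (Mus musculus) for inhibition, read by Griess assay, with stated times of 2 h and 18 h (on this read-out higher numbers stand for weaker inhibition and lower numbers for stronger inhibition), compound 1 gives 22500 nM. Compound 2 reaches the limit of this assay, > 50000 nM, and no number. Compound 3 gives 21900 nM in this assay. The change from compound 2 to compound 1 is a group of 5 heavy atoms (4 carbon, 1 oxygen; one five-membered aromatic ring with 1 hetero atom) in place of a group of 6 heavy atoms (4 carbon, 2 oxygen; one five-membered non-aromatic ring with 1 hetero atom), on a saturated chain carbon, two bonds along the chain from a double-bonded ring carbon; it made an at least 2.2-fold lower number from compound 2 to compound 1 (0.34 log units; beyond the scatter), a step known only as a bound because the limit of > 50000 nM in this assay, at which 1 of the 3 values shown sits, holds compound 2. The difference between the core of compound 2 and the core of compound 3 is not broken down here. Compound 4 carries the same kind of change relative to compound 3: a group of 5 heavy atoms (4 carbon, 1 oxygen; one five-membered aromatic ring with 1 hetero atom) in place of a group of 6 heavy atoms (4 carbon, 2 oxygen; one five-membered non-aromatic ring with 1 hetero atom), on a saturated chain carbon, two bonds along the chain from a saturated ring carbon; here the chain hangs from a saturated ring carbon rather than from a double-bonded ring carbon. Compound 4 is expected to take a 1.8-fold lower number from compound 3 to compound 4 (0.26 log units; within the scatter) in this assay, resting on an at least 2.2-fold lower number from compound 2 to compound 1 (0.34 log units; beyond the scatter) and on compound 3 at 21900 nM. The estimate for compound 4 is 12000 nM, expected to fall between 5000 nM and 30000 nM.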

Compound 4, half-maximal inhibitory concentration: > 50000 nM
Compound 4: no number, only a limit (the forecaster's own chance of this, stated with the estimate: 10%); middle value at least 4.1-fold (0.61 log units) from the limit.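

On the core of compound 3, furan-3-yl in place of the butenolide gave an at least 2.2-fold higher number from compound 3 to compound 4 (0.35 log units; beyond the scatter), a step known only as a bound since compound 4 reached a limit of the assay and gave no number. The change therefore does not carry over from one core to the other in this assay, and the two steps run in opposite directions: the same change on two cores in this assay, an at least 2.2-fold lower number (0.34 log units; beyond the scatter) from compound 2 to compound 1 and an at least 2.2-fold higher number (0.35 log units; beyond the scatter) from compound 3 to compound 4, at least 5.0-fold (0.70 log units) apart, beyond the scatter of two such steps. This does not show the true size of either step, and two cores are too few to support a rule for the series: the limit of > 50000 nM in this assay, at which 2 of the 4 values shown sit.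

The compounds shown leave open whether the reversal goes with the chain hanging from a saturated ring carbon rather than a double-bonded ring carbon, or with some other difference in the two cores. Also open, on these data alone, is how other groups in the same place, such as a carboxylic acid, an amine or a longer chain, would read in this assay on each core.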